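The source may hold more compounds than are shown below. What is called first, only, known or untested is meant among the compounds shown, and "the series" means these compounds.

Working notes on the series. Going by the values given here, in a physicochemical assay for lipophilicity, read by HPLC, at pH 7.4 (on this read-out lower numbers stand for lower lipophilicity and higher numbers for higher lipophilicity), compound 1 (`Cc1ccc(-c2cc(-c3ccc(S(C)(=O)=O)cc3)cnc2N)cn1`) gives 1.8 and holds the lower of the two numbers so far. Compound 2 (`Cc1ccc(-c2cc(-c3ccc(S(C)(=O)=O)cc3)cnc2N)cc1C(F)(F)F`) gives 3.6 on the same scale. The gap between these two compounds lies beyond the scatter. Compound 3 (`CS(=O)(=O)c1ccc(-c2cnc(N)c(-c3ccc(C#N)cc3)c2)cc1`) has 4-cyanophenyl in place of 6-methylpyridin-3-yl on an aromatic carbon and has no reading yet. Among the compounds with values here, no step between measured compounds bears on this change. Compound 2 at 3.6 serves as a reference for the expectation. Within the data shown here, an upward step is expected (a number 0.60 log units higher from compound 1 to compound 3 (beyond the scatter)) with no measured step behind it. For compound 3 the estimated value is 2.4 (expected range 1.9 to 2.9).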

Compound 3, distribution coefficient: 2.4
Estimate against measurement, compound 3: no gap at the digits printed, within the range that was stated.
By their numbers in this assay, from the lowest: compound 1; then compound 3; then compound 2.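

In this assay this position, ortho to an amino group, now has its first measured step: the change gives a number 0.60 log units higher from compound 1 to compound 3 (beyond the scatter) with 4-cyanophenyl in place of 6-methylpyridin-3-yl. A ring with one hetero atom gives way to a ring of carbon only and a triple bond enters, while the counts of hydrogen-bond donors and acceptors stay the same. Nothing measured here explains the step. The compounds shown do not separate the part played by the nitrile from that of the ring nitrogen, or from that of the lost methyl. On these data alone, how a plain phenyl would read at this position stays open.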